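This account rests on a few compounds, and the source may have more. Where it says the series, first, only, none or still open, it means among the compounds named here.

Three compounds share one core and differ only in the chlorophenyl group on an amine nitrogen in a ring. In a functional assay on HeLa cells (Homo sapiens) for antiproliferative activity, read by MTT assay, with a stated time of 48 h (on this read-out lower numbers stand for stronger inhibition and higher numbers for weaker inhibition), compound 3 `S=c1oc(-c2ccc3c(c2)OCCO3)nn1CN1CCN(c2ccccc2Cl)CC1` gives 37400 nM. Compound 2 `S=c1oc(-c2ccc3c(c2)OCCO3)nn1CN1CCN(c2cccc(Cl)c2)CC1` gives 47200 nM in this assay. Compound 1 `S=c1oc(-c2ccc3c(c2)OCCO3)nn1CN1CCN(c2ccc(Cl)cc2)CC1` reaches only a limit of this assay, > 50000 nM, so no number is known for it (the limit of > 50000 nM in this assay, at which 1 of the 3 values shown sits). Compound 3 thus holds the lower of the two numbers shown, yet the step of a 1.3-fold lower number from compound 2 to compound 3 (0.10 log units; within the scatter) is small, as are an at least 1.0-fold lower number from compound 1 to compound 2 (0.02 log units; that floor lies within the scatter) and an at least 1.3-fold lower number from compound 1 to compound 3 (0.12 log units; that floor lies within the scatter). Compound 4 `S=c1oc(-c2ccc3c(c2)OCCO3)nn1CN1CCN(c2ccccn2)CC1` is not yet measured; the change from compound 3 is pyridin-2-yl in place of 2-chlorophenyl on an amine nitrogen in a ring. The measured steps only move the chlorine around the phenyl ring and never exchange that ring for pyridine, so they give no footing for a step beyond the scatter. The expectation for compound 4 is therefore a 1.2-fold higher number from compound 3 to compound 4 (0.08 log units; within the scatter). Compound 4 is estimated at 45000 nM in this assay, within a range from 18000 nM to 100000 nM.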

Compound 4, half-maximal inhibitory concentration: 25100 nM
Compound 4: the middle estimate sits 1.8-fold (0.25 log units) above what was measured; low and high end bracket the measured number.
By their numbers in this assay, from the lowest: compounds 4, 3 and 2 (each within the scatter of the next). At a limit, above all of these: compound 1.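

The earlier compounds shown here only moved the chlorine around the phenyl ring; compound 4 shows that the whole 2-chlorophenyl group can be exchanged at this place. Pyridin-2-yl has no chlorine and brings a ring nitrogen and a hydrogen-bond acceptor, yet the result stays within the scatter, both in the step (a 1.5-fold lower number from compound 3 to compound 4 (0.17 log units; within the scatter)) and in the step (a 1.9-fold lower number from compound 2 to compound 4 (0.27 log units; within the scatter)). The step (an at least 1.9-fold lower number from compound 1 to compound 4 (0.29 log units; that floor lies within the scatter)) gives only a floor, since its starting value is a limit and not a number: the limit of > 50000 nM in this assay, at which 1 of the 4 values shown sits.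

As far as these compounds go, whether any group at this place gives a step beyond the scatter remains open. An unsubstituted phenyl, pyridin-3-yl, pyridin-4-yl or a phenyl ring bearing a carboxylic acid or an amine could test this.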